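A few compounds are considered here, and "the series" means these few. Any claim that something is new, unique, unknown or untested is made for them only; others in the source may bear on it.

The study places three compounds on a shared core, and only two of them carry a reading so far. Going by the values given here, compound 1 `CC(C)c1cccc(C(C)C)c1NC(=O)NS(=O)(=O)N(C(C)C)C1CCCCC1` is the one with a measured number: in an assay on liver for inhibition of sterol O-acyltransferase 1 (Rattus norvegicus), using microsomes (on this read-out lower numbers stand for stronger inhibition and higher numbers for weaker inhibition), compound 1 gives 360 nM. Among the compounds with values here, compound 2 `CC(C)c1cccc(C(C)C)c1OC(=O)NS(=O)(=O)N1CCOCC1` differs from compound 1 both in the linker to the sulfonyl group and in what sits on the sulfonyl sulfur, so the two values show only that one is a number and the other is not. In this assay compound 2 gives > 100000 nM, which is a limit of the assay rather than a number. This reading is the limit of > 100000 nM in this assay, at which 1 of the 2 values shown sits. Compound 3 `CC(C)c1cccc(C(C)C)c1OC(=O)NS(=O)(=O)Nc1ccccc1` keeps the linker of compound 2 and changes the group on the sulfonyl sulfur: anilino in place of morpholin-4-yl on a sulfonyl sulfur. Within the data shown here, no measured pair differs in this one place, so the size of the step has to be judged from compound 2 alone, and its value is a limit. The step from compound 2 to compound 3 is estimated as an at least 2.5-fold lower number from compound 2 to compound 3 (0.39 log units; beyond the scatter) in this assay, toward stronger inhibition. Compound 3 is therefore expected to give about 40000 nM in this assay, within a range from 4000 nM to 300000 nM, with a real chance that only a limit is reported once more.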

Compound 3, half-maximal inhibitory concentration: 38100 nM
For compound 3 the middle estimate is 1.0-fold (0.02 log units) above the measured one, and the stated range covers the measured number.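

The sulfonyl sulfur of this linker proved to be a position where a single exchange moves the reading: anilino in place of morpholin-4-yl gives an at least 2.6-fold lower number from compound 2 to compound 3 (0.41 log units; beyond the scatter) in this assay. Going by these compounds alone, compound 3 thus supplies the first true number for this linker, whereas the earlier compounds offered only a limit for it and a value on a different linker. The step is a lower bound and its full size cannot be read, because the reading of compound 2 is a limit and not a number: the limit of > 100000 nM in this assay, at which 1 of the 3 values shown sits.

The compounds shown leave open whether the step belongs to the aromatic ring of carbon only or to the hydrogen-bond donor that enters with it, a question that a group such as N-methylanilino or cyclohexylamino on the same sulfur would help to separate. They also leave open how much of the distance between compound 3 and compound 1 lies in the linker and how much in the group on the sulfur, since these two compounds differ in more than one place.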